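The source may hold more compounds than are shown below. What is called first, only, known or untested is meant among the compounds shown, and "the series" means these compounds.

Measured so far in a functional assay on HCT-116 cells (Homo sapiens) for antiproliferative activity, read by MTT assay, with a stated time of 72 h; on this read-out higher numbers stand for weaker inhibition and lower numbers for stronger inhibition:
- compound 1 `NC1=NC2(CCOCC2)N(OCCCOc2cccc(Cl)c2Cl)C(N)=N1`: 5 nM
- compound 2 `NC1=NC2(CCOCC2)N(OCCCOc2ccccc2Br)C(N)=N1`: 30 nM
- compound 3 `NC1=NC2(CCOCC2)N(OCCCOc2cccc(Cl)c2)C(N)=N1`: 120 nM

Compound 3, at 120 nM, gives the highest number of the three and so the weakest inhibition so far. Compound 4 `Cc1ccc(OCCCON2C(N)=NC(N)=NC23CCOCC3)cc1` differs from it in one place: 4-methylphenyl in place of 3-chlorophenyl on an oxygen on a saturated carbon.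

Within the data shown here, no measured compound carries 4-methylphenyl, so no step shows this change directly. The closest evidence comes from the three steps among the other phenyl groups. These are a 6.0-fold higher number from compound 1 to compound 2 (0.78 log units; beyond the scatter), which is modest, a 4.0-fold higher number from compound 2 to compound 3 (0.60 log units; beyond the scatter), also modest, and a 24-fold higher number from compound 1 to compound 3 (1.38 log units; beyond the scatter), which is large and removes a chloro. All three lie beyond the scatter, so a change in this group is not expected to pass unnoticed in this assay. Compound 4 keeps no chloro, and the removal of one in a 24-fold higher number from compound 1 to compound 3 (1.38 log units; beyond the scatter) raised the number, so a modest step upward is expected, though a step in the other direction cannot be excluded. The expected change is a 2.1-fold higher number from compound 3 to compound 4 (0.32 log units; beyond the scatter). For compound 4 the estimate is 250 nM, with an expected range of 70 nM to 900 nM.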

Compound 4, half-maximal inhibitory concentration: 2390 nM
Beside the measured number, compound 4's estimate is 9.6-fold (0.98 log units) below it, outside the stated range (above it).
By their numbers in this assay, from the lowest: compound 1; then compound 2; then compound 3; then compound 4.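

In this assay, exchanging 3-chlorophenyl for 4-methylphenyl on the oxygen on a saturated carbon gives a 20-fold higher number from compound 3 to compound 4 (1.30 log units; beyond the scatter), a large step even though the two groups match in heavy-atom count, in their single six-membered aromatic ring and in having no hydrogen-bond donors or acceptors. With an 80-fold higher number from compound 2 to compound 4 (1.90 log units; beyond the scatter) and a 480-fold higher number from compound 1 to compound 4 (2.68 log units; beyond the scatter), compound 4 is the weakest of the four, and the span at this position proves much wider than the three halogen-bearing compounds had shown, with the one compound lacking a halogen at the weak end. Nothing available here gives a measured reason for this loss of activity.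

The change alters both the substituent and its place on the ring, and the compounds shown do not separate these two parts, so it remains open whether the methyl group, the loss of chloro or the new ring position carries the step. From the compounds shown here alone, how an unsubstituted phenyl, or a phenyl bearing an amine or a carboxylic acid, would read at this position also stays open.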